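Swapping a methyl for chlorine on the acid-bearing ring

A few compounds are considered here, and "the series" means these few. Any claim that something is new, unique, unknown or untested is made for them only; others in the source may bear on it.

Three compounds share a core in which two aromatic rings are joined by a four-carbon ether chain. In an assay on HEK293 cells for positive allosteric modulation of metabotropic glutamate receptor 2 (Rattus norvegicus), read by thallium flux, with a stated time of 2.5 min (a higher number here means that more compound is needed for the effect, a lower number that less compound is needed), compound 1 `Cc1cc(C(=O)O)ccc1OCCCCOc1ccc(C(=O)CC(C)C)c(O)c1C` gives 192 nM, compound 2 `Cc1c(OCCCCOc2ccccc2C(=O)O)ccc(C(=O)CC2CCCC2)c1C` gives 2580 nM, and compound 3 `CCCC(=O)c1ccc(OCCCCOc2cccc(C(=O)O)c2C)c(C)c1O` gives 52 nM. Compound 1 thus holds the second highest of the three numbers, needing more compound than compound 3 and less than compound 2. Compound 4 `Cc1c(OCCCCOc2ccc(C(=O)O)cc2Cl)ccc(C(=O)CC(C)C)c1O` keeps everything in compound 1 except one change: chloro in place of methyl on an aromatic carbon, ortho to a large group and meta to a carboxy group. Within the data shown here, no measured pair here isolates that swap, so the step from compound 1 to compound 4 is expected to stay within the scatter, a 1.0-fold higher number from compound 1 to compound 4 (0.02 log units; within the scatter). Compound 4 is therefore estimated at 200 nM, between 80 nM and 500 nM.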

Compound 4, half-maximal effective concentration: 96 nM
Estimate against measurement, compound 4: 2.1-fold (0.32 log units) above; the measured number falls inside the stated range.
By their numbers in this assay, from the lowest: compounds 3, 4 and 1 (each within the scatter of the next, the first and the last beyond it); then compound 2.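

Among these compounds, this is the first direct look at this position, ortho to a large group and meta to a carboxy group, since the earlier compounds differ from one another in more than one place. In this assay, chloro in place of methyl gives a 2.0-fold lower number from compound 1 to compound 4 (0.30 log units; within the scatter) and so leaves the two groups indistinguishable here, which means this position accepts either. Nothing on hand explains this result.

As far as these compounds go, whether a fluoro, bromo or methoxy group would read the same on this carbon stays open. So does whether this swap would read the same on a core other than that of compound 1.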